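The source may hold more compounds than are shown below. What is called first, only, known or untested is meant among the compounds shown, and "the series" means these compounds.

Measured so far:
- compound 1 `O=c1c(Cc2coc3cccc(OCC4CCCCC4)c3c2=O)coc2cc(Cl)ccc12`: > 10000 nM (a limit, not a number)
- compound 2 `COc1ccc2c(=O)c(Cc3coc4cccc(OCC5CCCCC5)c4c3=O)coc2c1`: 1450 nM

Going by the values given here, in a functional assay on HCT-15 cells (Homo sapiens) for antiproliferative activity, read by XTT assay (on this read-out higher numbers stand for weaker inhibition and lower numbers for stronger inhibition), compound 2 gives 1450 nM, the only true number so far. Compound 3 `O=c1c(Cc2coc3cccc(OCC4CCCCC4)c3c2=O)coc2cc(O)ccc12` differs from it in one place: hydrogen in place of methyl on an oxygen on an aromatic ring, methoxy to hydroxy. Among the compounds with values here, no measured step covers this change directly.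

The nearest evidence is an at least 6.8-fold lower number from compound 1 to compound 2 (0.83 log units; beyond the scatter), which is methoxy in place of chloro on an aromatic carbon and so concerns the same substituent. That step is open on one side, as its size rests on (the limit of > 10000 nM in this assay, at which 1 of the 2 values shown sits). It shows that the read-out can respond strongly to a change of this substituent, but it says little about direction here.

Compound 3 keeps an oxygen on that carbon, so the expectation is anchored on compound 2 at 1450 nM. The expected move is small and towards a higher number, with no clear shift beyond the scatter: a 1.4-fold higher number from compound 2 to compound 3 (0.14 log units; within the scatter). The range is kept wide, and a result at the assay limit remains possible.

The estimate for compound 3 is 2000 nM, with an expected range of 600 nM to 9000 nM.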

Compound 3, half-maximal inhibitory concentration: 2110 nM
Beside the measured number, compound 3's estimate is 1.1-fold (0.02 log units) below it; the measured number falls inside the stated range.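

In this assay, taking the methyl off the oxygen gives a 1.5-fold higher number from compound 2 to compound 3 (0.16 log units; within the scatter), so on this read-out methoxy and hydroxy on this aromatic carbon cannot be told apart. The comparison with chloro now rests on two steps, an at least 4.7-fold lower number from compound 1 to compound 3 (0.67 log units; beyond the scatter) and an at least 6.8-fold lower number from compound 1 to compound 2 (0.83 log units; beyond the scatter): either oxygen substituent gives a lower number than chloro, beyond the scatter, and none of the three compounds goes against this. What the hydroxy compound adds is that this difference from chloro does not depend on the methyl, though the full size of both steps stays unknown, as each is open on one side: the limit of > 10000 nM in this assay, at which 1 of the 3 values shown sits.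

On these data alone, whether this tolerance extends beyond the two oxygen substituents remains open, and an amine, a carboxylic acid or a longer chain such as ethoxy on the same aromatic carbon would test it. As far as these compounds go, all three compounds also share the rest of the structure, so it is equally open whether the same order of substituents would hold with a change elsewhere on the shared core.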